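Aryl swap from compound 2 to compound 3

The source may report more compounds than this note shows. Statements on the series, on what has been measured and on what is new or still open speak of the compounds shown alone.

Measured so far:
compound 1 `C/C(=N\NC(=S)NCCCCCC(=O)NO)c1ccc(Br)cc1`: 34.6 nM
compound 2 `C/C(=N\NC(=S)NCCCCCC(=O)NO)c1ccc(F)cc1`: 62.9 nM

In an assay on isolated protein for inhibition of protein deacetylase HDAC6 (Homo sapiens), read by fluorescence, with a stated time of 60 min (on this read-out higher numbers stand for weaker inhibition and lower numbers for stronger inhibition), compound 1 gives 34.6 nM and compound 2 gives 62.9 nM; the step is a 1.8-fold higher number from compound 1 to compound 2 (0.26 log units; within the scatter), so compound 2 stands at the higher of the two numbers, nearest compound 1 and within the scatter of it. Compound 3 `C/C(=N\NC(=S)NCCCCCC(=O)NO)c1cccc(Br)c1` differs from compound 2 by 3-bromophenyl in place of 4-fluorophenyl on a carbon with a double bond to nitrogen. Among the compounds with values here, only the step of a 1.8-fold higher number from compound 1 to compound 2 (0.26 log units; within the scatter) bears on this change, and it stayed within the scatter; no measured step covers a 3-bromophenyl. Compound 3 is therefore expected to move by a 1.6-fold lower number from compound 2 to compound 3 (0.20 log units; within the scatter), nothing beyond the scatter in this assay. Compound 3 is estimated at 40 nM, within 15 nM to 110 nM.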

Compound 3, half-maximal inhibitory concentration: 37.7 nM
Estimate against measurement, compound 3: 1.1-fold (0.03 log units) above; the range from low to high includes it.
By their numbers in this assay, from the lowest: compounds 1, 3 and 2 (each within the scatter of the next).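

In this assay, 3-bromophenyl in place of 4-bromophenyl gives the first comparison of two bromophenyl groups on the carbon with a double bond to nitrogen, and the step stays within the scatter (a 1.1-fold higher number from compound 1 to compound 3 (0.04 log units; within the scatter)). 3-Bromophenyl in place of 4-fluorophenyl also stays within the scatter (a 1.7-fold lower number from compound 2 to compound 3 (0.22 log units; within the scatter)), so the three aryl groups shown read alike. No supporting data bear on these readings.

Still open, from the compounds shown here alone, is whether an amine or a carboxylic acid on the phenyl ring would leave the number in this range. Also open, going by these compounds, is how a pyridine ring in place of the phenyl would read.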